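Chain swap on the shared core: compound 1 to compound 3

The source may report more compounds than this note shows. Statements on the series, on what has been measured and on what is new or still open speak of the compounds shown alone.

For the measured compounds named here, compound 1 `Cn1c(-c2ccccc2C(F)(F)F)nnc1C12CCC(CCS(C)(=O)=O)(CC1)CC2` gives 96% in a functional assay on the whole organism (strain ICR) for inhibition, with Mus musculus as the target, with a stated time of 4 h, at a dose of 10 mg/kg by the oral route (on this read-out higher numbers stand for more inhibition at the one dose given (going by the name of the read-out) and lower numbers for less inhibition), the highest of the two numbers so far; compound 2 `CCS(=O)(=O)CCC12CCC(c3nnc(-c4ccccc4Br)n3C)(CC1)CC2` gives 86% in this assay, a gap within the scatter, so the two are not ordered. Compound 3 `Cn1c(-c2ccccc2C(F)(F)F)nnc1C12CCC(CCCC(C)(F)F)(CC1)CC2` carries the change (2,2-difluoropropyl in place of methylsulfonyl on a saturated chain carbon, two bonds along the chain from a saturated ring carbon). Going by the values given here, no measured step of this kind exists. The expected step is a number 16 percentage points lower from compound 1 to compound 3 (beyond the scatter), a small loss or none beyond the scatter, resting on the high number of compound 1 at 96%. Compound 3 is therefore estimated to give 80% in this assay, within a range from 55% to 98%.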

Compound 3, a percentage reported as inhibition, in the whole organism at one dose (the size of the read-out at that dose, not a potency): 99%
Estimate against measurement, compound 3: 19 percentage points below; measured number above the stated range.
By their numbers in this assay, from the lowest: compounds 2, 1 and 3 (each within the scatter of the next, the first and the last beyond it).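

In this assay, replacing methylsulfonyl with 2,2-difluoropropyl on a saturated chain carbon, two bonds along the chain from a saturated ring carbon, gives a number 3 percentage points higher from compound 1 to compound 3 (within the scatter). This position therefore accepts a group without hydrogen-bond acceptors, with no loss of inhibition beyond the scatter at this one dose, which is not a potency read-out. Nothing available explains this result. Open, going by these compounds, is whether an amine, a carboxylic acid or a longer chain in place of methylsulfonyl would keep this inhibition. Also open, on these data alone, is whether compound 1 and compound 3 would separate at a lower dose.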